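A few compounds are considered here, and "the series" means these few. Any claim that something is new, unique, unknown or untested is made for them only; others in the source may bear on it.

Compound 1, `O=c1c(O)c(-c2ccccc2)oc2cc(OCc3ccccc3Br)cc(O)c12`. In an ADME assay on Huh-5-2 cells (Homo sapiens) for cytotoxicity, read by WST assay, with a stated time of 3 days (on this read-out lower numbers stand for higher toxicity in this test and higher numbers for lower toxicity in this test), compound 1 gives > 100000 nM, a limit of the assay.
Compound 2, `COc1ccccc1COc1cc(O)c2c(=O)c(O)c(-c3ccccc3)oc2c1`. In this assay compound 2 gives > 100000 nM, also a limit.
Compound 3, `O=c1c(O)c(-c2ccccc2)oc2cc(OCc3cccc([N+](=O)[O-])c3)cc(O)c12`. In this assay compound 3 gives 76000 nM.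

Among the compounds with values here, compound 3 thus holds the only number among the three; the other two sit at the limit of > 100000 nM in this assay, at which 2 of the 3 values shown sit. Compound 4, `N#Cc1ccc(COc2cc(O)c3c(=O)c(O)c(-c4ccccc4)oc3c2)cc1`, differs from compound 3 by 4-cyanophenyl in place of 3-nitrophenyl on a saturated chain carbon bound to an oxygen on an aromatic ring. The steps that lead to compound 3 are small: an at least 1.3-fold lower number from compound 1 to compound 3 (0.11 log units; that floor lies within the scatter) and an at least 1.3-fold lower number from compound 2 to compound 3 (0.11 log units; that floor lies within the scatter), neither clearly beyond the scatter. For compound 4 no step beyond the scatter is therefore expected in this assay, so a value near that of compound 3 is estimated. Compound 4 is expected at 90000 nM, between 45000 nM and 180000 nM, meaning an expected step of a 1.2-fold higher number from compound 3 to compound 4 (0.07 log units; within the scatter).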

Compound 4, half-maximal cytotoxic concentration: 94000 nM
Estimate against measurement, compound 4: 1.0-fold (0.02 log units) below; the range from low to high includes it.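

In this assay, compound 4 shows that at this place, on a saturated chain carbon bound to an oxygen on an aromatic ring, 4-cyanophenyl can replace 3-nitrophenyl without a step beyond the scatter: a 1.2-fold higher number from compound 3 to compound 4 (0.09 log units; within the scatter). The comparisons with the two compounds held at a limit add only floors within the scatter: an at least 1.0-fold lower number from compound 2 to compound 4 (0.02 log units; that floor lies within the scatter), and an at least 1.0-fold lower number from compound 1 to compound 4 (0.02 log units; that floor lies within the scatter).

As far as these compounds go, whether an amine or a carboxylic acid on this phenyl ring, or a longer chain at this place, would give a clear step stays open. Any ranking of these compounds also stays open, with some of the values held at a limit: the limit of > 100000 nM in this assay, at which 2 of the 4 values shown sit.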